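This account rests on a few compounds, and the source may have more. Where it says the series, first, only, none or still open, it means among the compounds named here.

Measured in a functional assay on HT cells (Homo sapiens) for antiproliferative activity, read by fluorescence, with a stated time of 72 h; a higher number here means a weaker inhibitor of growth, a lower number a stronger inhibitor of growth:
compound 1 `CC(C)c1n[nH]c2c(NCc3ccc(-c4ccccn4)cc3)nc(SCCO)nc12`: 48 nM
compound 2 `CC(C)c1n[nH]c2c(NCc3ccc(-c4ccccn4)cc3)nc(SC3CCCCC3N)nc12`: 139 nM

Of these two, compound 2 has the higher number, so it is the weaker inhibitor of growth, and its gap to compound 1 lies beyond the scatter. The next compound to consider is compound 3 `CCC(CO)Sc1nc(NCc2ccc(-c3ccccn3)cc2)c2[nH]nc(C(C)C)c2n1`, which keeps the shared core and differs only in the group on the sulfur: 1-(hydroxymethyl)propyl in place of 2-aminocyclohexyl on a sulfur. Here, 1-(hydroxymethyl)propyl stands in place of 2-aminocyclohexyl.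

Among the compounds with values here, one measured step bears on this change: a 2.9-fold higher number from compound 1 to compound 2 (0.46 log units; beyond the scatter). That modest step came with 2-aminocyclohexyl replacing 2-hydroxyethyl on a sulfur. The group entering compound 3 is, like 2-hydroxyethyl, a chain carrying a hydroxy group, so compound 1, at 48 nM, is the closer guide. As far as these compounds go, a single step is thin evidence, and the effect of the branched chain is untested. Even so, a lower number in this assay is expected, in a step of similar size to that one but in the opposite direction. The expected change is a 2.3-fold lower number from compound 2 to compound 3 (0.36 log units; beyond the scatter). For compound 3 the estimate is 60 nM, with an expected range from 25 nM to 140 nM.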

Compound 3, concentration for 50% growth inhibition: 255 nM
Compound 3: middle estimate off by 4.3-fold (0.63 log units), on the low side; the whole stated range lies below it.
By their numbers in this assay, from the lowest: compound 1; then compounds 2 and 3 (each within the scatter of the next).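

In this assay, a hydroxy group on the chain is not enough to hold the standing of compound 1: ethyl in place of hydrogen on the saturated chain carbon bound to a saturated chain carbon and a sulfur gives a 5.3-fold higher number from compound 1 to compound 3 (0.73 log units; beyond the scatter) in a single change. Replacing 2-aminocyclohexyl with 1-(hydroxymethyl)propyl gives a 1.8-fold higher number from compound 2 to compound 3 (0.26 log units; within the scatter) and so separates neither group from the other in this measurement, even though one carries a carbon-only ring and an amine and the other an open chain and a hydroxy group. Nothing shown explains either step.

The compounds shown leave open how the number responds to the size of the added branch, as a methyl on that same chain carbon would show, and whether the hydroxy group matters there at all, as a plain sec-butyl group would show. They also leave open whether the amine of compound 2 behaves differently without its ring, which a 2-aminoethyl group on the sulfur could test against the 2-hydroxyethyl group of compound 1.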